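The compounds below may be only part of what the source reports. "The series", "measured", "known", "first", "only" and "open" are said of these compounds alone.

Compound 1 `CCOC(=O)[C@@H]1C[C@@]23CN(C)C[C@@H](CCC4=C2[C@@H]1CC4=O)C31CC[C@](CC)(OC)OC1` — in a functional assay on SW480 cells (Homo sapiens) for cytotoxicity, read by MTT assay, with a stated time of 48 h (on this read-out higher numbers stand for weaker inhibition and lower numbers for stronger inhibition), compound 1 gives > 40000 nM, which is a limit of the assay, not a number.
Compound 2 `CCO[C@@]1(CC)CCC2(CO1)[C@@H]1CCC3=C4[C@H](CC3=O)[C@H](C(=O)OC)C[C@@]42CN(C)C1` — in this assay compound 2 gives > 40000 nM, again a limit.
Compound 3 `CC[C@]1(OC)CCC2(CO1)[C@@H]1CCC3=C4[C@H](CC3=O)[C@H](C(=O)OC)C[C@@]42CN(C)C1` — in this assay compound 3 gives > 40000 nM, again a limit.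

Compound 3 therefore stands at the limit of this assay, as do both of its measured neighbours; this is described by the limit of > 40000 nM in this assay, at which 3 of the 3 values shown sit. The step from compound 1 to compound 3 is a step that the two limits leave unreadable from compound 1 to compound 3, and the step from compound 2 to compound 3 is a step that the two limits leave unreadable from compound 2 to compound 3: with a limit on both sides, neither step has a readable size or direction.

Compound 4 `CC[C@@]1(OC)CCC2(CO1)[C@@H]1CCC3=C4[C@H](CC3=O)[C@H](C(=O)OC)C[C@@]42CN(C)C1` differs from compound 3 only in this way: the two compounds have the same atoms and bonds; at least one stereo element is drawn with a configuration in one of them and without one in the other: 1 of 6 stereo elements differ; a stereocentre at a saturated ring carbon is drawn R in compound 3 and S in compound 4. Within the data shown here, no measured step bears on a change of this kind, and the steps that reach compound 3 are themselves unreadable, so no size or direction beyond the scatter can be expected from them. The estimate for compound 4 is that it also sits at or beyond the limit, with an expected step that the limit leaves unreadable from compound 3 to compound 4 from compound 3. Compound 4 is expected to give 50000 nM, within a range from 15000 nM to 200000 nM.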

Compound 4, half-maximal inhibitory concentration: > 40000 nM
Compound 4: only a limit was reported; the forecaster's own chance of this, stated with the estimate: 80%; the middle value is on the limit's open side.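

Among these compounds, compound 3 and compound 4 both sit at a limit of this assay and give no number, so no step between them can be read. The compounds shown leave open whether any configuration at that ring carbon gives a measurable value in this assay at all.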